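Chloro at a new position on the benzylidene ring

The source may report more compounds than this note shows. Statements on the series, on what has been measured and on what is new or still open speak of the compounds shown alone.

Measured compounds in a functional assay on DLD-1 cells (Homo sapiens) for cytotoxicity, read by MTT assay, with a stated time of 72 h; on this read-out higher numbers stand for weaker inhibition and lower numbers for stronger inhibition:
- compound 1 `Cc1c(/N=C/c2cccc(O)c2)c(=O)n(-c2ccccc2)n1C`: 372000000 nM
- compound 2 `Cc1c(/N=C/c2ccccc2Cl)c(=O)n(-c2ccccc2)n1C`: 417000000 nM
- compound 3 `Cc1c(/N=C/c2ccccc2)c(=O)n(-c2ccccc2)n1C`: 933000000 nM

Compound 3 gives the highest number of the three, so it is the weakest inhibitor here; compound 2 sits a 2.2-fold higher number from compound 2 to compound 3 (0.35 log units; beyond the scatter) and compound 1 sits a 2.5-fold higher number from compound 1 to compound 3 (0.40 log units; beyond the scatter) from it. Compound 4 `Cc1c(/N=C/c2ccc(Cl)cc2)c(=O)n(-c2ccccc2)n1C` differs from compound 3 by chloro in place of hydrogen on an aromatic carbon, sitting para to a large group. Among the measured compounds shown here, the closest precedent is the chloro already seen in compound 2, where removing it gave a 2.2-fold higher number from compound 2 to compound 3 (0.35 log units; beyond the scatter), a modest change. A modest lowering of the number is therefore expected, a 2.1-fold lower number from compound 3 to compound 4 (0.32 log units; beyond the scatter), though the new chloro sits elsewhere on the ring, so the size is uncertain. Compound 4 is estimated at 450000000 nM, with a range from 200000000 nM to 1000000000 nM.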

Compound 4, half-maximal inhibitory concentration: 631000000 nM
The estimate for compound 4 lay 1.4-fold (0.15 log units) below the measured number; measured number inside the range.
By their numbers in this assay, from the lowest: compounds 1, 2, 4 and 3 (each within the scatter of the next, the first and the last beyond it).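

In this assay, the chloro on the aromatic carbon para to a large group gives a step that stays within the scatter (a 1.5-fold lower number from compound 3 to compound 4 (0.17 log units; within the scatter)), so at this position it cannot be told apart from hydrogen. The change from 2-chlorophenyl and the change from 3-hydroxyphenyl also stay within the scatter (a 1.5-fold higher number from compound 2 to compound 4 (0.18 log units; within the scatter); a 1.7-fold higher number from compound 1 to compound 4 (0.23 log units; within the scatter)), so here the placement of the chloro shows no clear effect. Nothing available explains this result. On these data alone, whether an amine, a carboxylic acid or a longer chain at this position would move the number beyond the scatter remains open.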